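Pyridin-3-yl to pyridin-4-yl on compound 2

The source may hold more compounds than are shown below. What is called first, only, known or untested is meant among the compounds shown, and "the series" means these compounds.

In an ADME assay on L02 cells (Homo sapiens) for cytotoxicity, read by MTT assay, with a stated time of 24 h (a higher number here means a weaker inhibitor, a lower number a stronger inhibitor), compound 1 `Cc1ccc(S(=O)(=O)N2C/C(=C\c3cccnc3)C(=O)/C(=C/c3ccccc3C(F)(F)F)C2)cc1` gives 12300 nM, compound 2 `O=C1/C(=C/c2cccnc2)CN(S(=O)(=O)c2ccc([N+](=O)[O-])cc2)C/C1=C\c1ccccc1C(F)(F)F` gives 15700 nM and compound 3 `O=C1/C(=C/c2cccnc2)CN(S(=O)(=O)c2ccc(Cl)cc2)C/C1=C\c1ccccc1C(F)(F)F` gives 11900 nM. These three values lie within the scatter of one another, so compound 2 holds no rank among them. The measured steps are a 1.3-fold higher number from compound 1 to compound 2 (0.11 log units; within the scatter), a 1.3-fold lower number from compound 2 to compound 3 (0.12 log units; within the scatter) and a 1.0-fold lower number from compound 1 to compound 3 (0.01 log units; within the scatter). All three exchange methyl, nitro and chloro on an aromatic carbon.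

Compound 4 `O=C1/C(=C/c2ccncc2)CN(S(=O)(=O)c2ccc([N+](=O)[O-])cc2)C/C1=C\c1ccccc1C(F)(F)F` differs from compound 2 elsewhere: pyridin-4-yl in place of pyridin-3-yl on a double-bonded chain carbon bound to a double-bonded ring carbon. This is pyridin-4-yl in place of pyridin-3-yl on a double-bonded chain carbon bound to a double-bonded ring carbon. Among the compounds with values here, no measured step touches that place, so those three steps bear on it only indirectly. The expectation therefore rests on compound 2 at 15700 nM, with no direction favoured in this assay. The expected step, no larger than the scatter, is a 1.0-fold lower number from compound 2 to compound 4 (0.02 log units; within the scatter). For compound 4 the estimated value is 15000 nM, with an expected range of 8000 nM to 28000 nM.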

Compound 4, half-maximal inhibitory concentration: 18600 nM
For compound 4 the middle estimate is 1.2-fold (0.09 log units) below the measured one; the measured number falls inside the stated range.
By their numbers in this assay, from the lowest: compounds 3, 1, 2 and 4 (each within the scatter of the next).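

In this assay, the exchange of pyridin-3-yl for pyridin-4-yl on a double-bonded chain carbon bound to a double-bonded ring carbon gives a 1.2-fold higher number from compound 2 to compound 4 (0.07 log units; within the scatter). Within the data shown here, this is the first reading at this place, which the earlier exchanges of methyl, nitro and chloro on an aromatic carbon left untouched, and this single exchange also stays within the scatter, though it is seen only with nitro on the aromatic carbon. Nothing at hand accounts for the step or ties it to either group. As far as these compounds go, it remains open whether pyridin-2-yl or a plain phenyl at this place would also stay within the scatter. Also open, from the compounds shown here alone, is whether pyridin-4-yl gives the same reading with methyl or chloro in place of nitro on the aromatic carbon.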